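A few compounds are considered here, and "the series" means these few. Any claim that something is new, unique, unknown or untested is made for them only; others in the source may bear on it.

Measured compounds:
Compound 1, `CC(C)N(Cc1cccc(OCCCCCC(=O)O)c1)C(=O)c1ccccc1`, in an ADME assay on Raji cells (Homo sapiens) for cytotoxicity, read by CellTiter-Glo and resazurin assay, with a stated time of 72 h (a higher number here means that more compound is needed for the effect, a lower number that less compound is needed), gives > 26000 nM, a limit of the assay rather than a number.
Compound 2, `CC(C)N(Cc1cccc(OCCCCCC(=O)O)c1)C(=O)c1ccc(-c2cccc(-c3ccccc3)c2)cc1`, gives > 26000 nM, which is likewise a limit.
Compound 3, `CC(C)N(Cc1cccc(OCCCCCC(=O)O)c1)C(=O)c1ccc(-c2ccco2)cc1`, gives > 26000 nM, again a limit.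

Compound 2 therefore stands at the limit of > 26000 nM in this assay, at which 3 of the 3 values shown sit, and the two further values shown sit at the same limit, so nothing separates the three compounds on these numbers.

Compound 4, `CC(C)N(Cc1cccc(OCCCCCC(=O)O)c1)C(=O)c1ccc(-c2cccc(Oc3ccccc3)c2)cc1`, is not yet measured. It differs from compound 2 by phenoxy in place of phenyl on an aromatic carbon. The measured steps that bear on such a change at this position are a step that the two limits leave unreadable from compound 1 to compound 2, a step that the two limits leave unreadable from compound 1 to compound 3 and a step that the two limits leave unreadable from compound 2 to compound 3, and none of them can be read in size, since each rests on two limits. Among the measured compounds shown here, no measured step gives a direction or a size for the change at hand.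

Compound 4 is expected to remain at the limit, with an expected step that the limit leaves unreadable from compound 2 to compound 4, that is, none beyond the scatter. Compound 4 is estimated at 40000 nM, with a range from 20000 nM to 100000 nM.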

Compound 4, half-maximal effective concentration: > 18700 nM
Compound 4: a limit, no number; the forecaster's own chance of this, stated with the estimate: 85%; the middle value is on the limit's open side.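

Compound 2 and compound 4 each give a limit of the assay rather than a number, and the step between them cannot be read. The compounds shown leave open whether phenoxy in place of phenyl changes the concentration needed in this assay at all.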